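Moving a Hydroxyl Group Around a Shared Core

This account rests on a few compounds, and the source may have more. Where it says the series, first, only, none or still open, it means among the compounds named here.

Compound 1 `Oc1cccc(-c2cc(-c3cccc(O)c3)nc(-c3ccccc3O)c2)c1` gives > 50000 nM in an ADME assay on HEK293 cells (Homo sapiens) for cytotoxicity, read by CCK-8 assay, with a stated time of 4 days (a higher number here means a weaker inhibitor, a lower number a stronger inhibitor), a value that is a limit of the assay rather than a number.
Compound 2 `Oc1ccc(-c2cc(-c3cccc(O)c3)cc(-c3cccc(O)c3)n2)cc1` gives 1560 nM in this assay.
Compound 3 `Oc1ccc(-c2cc(-c3ccccc3O)cc(-c3ccccc3O)n2)cc1` gives 6990 nM in this assay.

Compound 2 differs from compound 1 by one change, (4-hydroxyphenyl in place of 2-hydroxyphenyl on an aromatic carbon), and the step was an at least 32-fold lower number from compound 1 to compound 2 (1.50 log units; beyond the scatter). Compound 4 `Oc1ccc(-c2cc(-c3ccccc3O)cc(-c3ccc(O)cc3)n2)cc1` is not yet measured; it differs from compound 3 by 4-hydroxyphenyl in place of 2-hydroxyphenyl on an aromatic carbon. This is the same kind of change, though what surrounds the place differs: in the first it sits meta to two 3-hydroxyphenyl groups, in the second meta to a 2-hydroxyphenyl group and meta to a 4-hydroxyphenyl group. How the cores of compound 1 and compound 3 differ is not broken down here. For compound 4 a lower number than compound 3 is expected, a step of a 3.9-fold lower number from compound 3 to compound 4 (0.59 log units; beyond the scatter), resting on the step of an at least 32-fold lower number from compound 1 to compound 2 (1.50 log units; beyond the scatter), but smaller since compound 3 starts from a measured number rather than a limit. Compound 4 is estimated at 1800 nM, between 600 nM and 5000 nM.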

Compound 4, half-maximal inhibitory concentration: 780 nM
Beside the measured number, compound 4's estimate is 2.3-fold (0.36 log units) above it; the measured number falls inside the stated range.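

The same swap, 4-hydroxyphenyl in place of 2-hydroxyphenyl, lowers the number on a second core, giving a 9.0-fold lower number from compound 3 to compound 4 (0.95 log units; beyond the scatter) in this assay, so the direction of the change holds on both cores shown. The size of the change does not carry over unchanged: the same change on two cores in this assay, an at least 32-fold lower number (1.50 log units; beyond the scatter) from compound 1 to compound 2 and a 9.0-fold lower number (0.95 log units; beyond the scatter) from compound 3 to compound 4, at least 3.5-fold (0.55 log units) apart, beyond the scatter of two such steps. From the compounds shown here alone, compound 1 gives a limit rather than a number, so the full size of the first step stays unknown, and two cores cannot establish a rule for the whole series: the limit of > 50000 nM in this assay, at which 1 of the 4 values shown sits.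

The compounds shown carry only hydroxyl groups on their phenyl rings. Going by these compounds, how this number would respond to an amine or a carboxylic acid in place of a hydroxyl remains open.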